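Working notes: bromo to acetamido at one aromatic carbon

The compounds below may be only part of what the source reports. "The series", "measured", "known", "first", "only" and "open" are said of these compounds alone.

- compound 1 `Cc1ccc(S(=O)(=O)N2C/C(=C\c3cccnc3)C(=O)/C(=C/c3ccccc3F)C2)cc1` gives 9700 nM
- compound 2 `O=C1/C(=C/c2cccnc2)CN(S(=O)(=O)c2ccc([N+](=O)[O-])cc2)C/C1=C\c1ccccc1F` gives 5600 nM
- compound 3 `O=C1/C(=C/c2cccnc2)CN(S(=O)(=O)c2ccc(Br)cc2)C/C1=C\c1ccccc1F` gives 12800 nM

All three values come from a functional assay on QGY-7703 cells (Homo sapiens) for cytotoxicity, read by MTT assay, with a stated time of 24 h (a higher number here means a weaker inhibitor, a lower number a stronger inhibitor), and lie close together. Compound 3 cannot be separated from compound 1, with a 1.3-fold higher number from compound 1 to compound 3 (0.12 log units; within the scatter), but it does stand apart from compound 2, with a 2.3-fold higher number from compound 2 to compound 3 (0.36 log units; beyond the scatter).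

Compound 4 `CC(=O)Nc1ccc(S(=O)(=O)N2C/C(=C\c3cccnc3)C(=O)/C(=C/c3ccccc3F)C2)cc1` carries acetamido in place of bromo on an aromatic carbon, para to a large group (acetamido in place of bromo on an aromatic carbon). Within the data shown here, no measured compound has acetamido, so only the swaps at this same place bear on the change. Besides the two steps above, there is a 1.7-fold lower number from compound 1 to compound 2 (0.24 log units; within the scatter). The largest of the three is modest, so a large move in this assay is not expected. Any shift is expected toward a lower number, though none beyond the scatter is anticipated. The estimate means a 1.4-fold lower number from compound 3 to compound 4 (0.15 log units; within the scatter). For compound 4 the estimated value is 9000 nM, with an expected range from 4500 nM to 18000 nM.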

Compound 4, half-maximal inhibitory concentration: 9640 nM
For compound 4 the middle estimate is 1.1-fold (0.03 log units) below the measured one; the measured number falls inside the stated range.
By their numbers in this assay, from the lowest: compounds 2, 4, 1 and 3 (each within the scatter of the next, the first and the last beyond it).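

Acetamido, a larger group than bromo that brings a hydrogen-bond donor and acceptor, leaves the read-out in this assay unmoved at this aromatic carbon: a 1.3-fold lower number from compound 3 to compound 4 (0.12 log units; within the scatter) and a 1.7-fold higher number from compound 2 to compound 4 (0.24 log units; within the scatter) and a 1.0-fold lower number from compound 1 to compound 4 (0.00 log units; within the scatter) all stay within the scatter. Among these compounds, the series therefore still holds only one step beyond the scatter at this place, the one between compound 2 and compound 3, and the amide joins the methyl, nitro and bromo compounds in one narrow band without separating from any of them. Nothing available bears on the reason for this flat response.

From the compounds shown here alone, whether the flat response extends to a carboxylic acid, an amine or a longer chain at this carbon stays open. Going by these compounds, all four compounds share the rest of the core, so how the read-out responds to changes elsewhere also stays open.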